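The compounds below may be only part of what the source reports. "The series", "measured", "known", "first", "only" and "open" are said of these compounds alone.

In an ADME assay on L929 cells (Mus musculus) for cytotoxicity, read by resazurin assay, with a stated time of 48 h (on this read-out lower numbers stand for higher toxicity in this test and higher numbers for lower toxicity in this test), three related compounds have been measured so far. Compound 1 `C=Cn1c2ccc([N+](=O)[O-])cc2c(=O)n1Cc1ccccc1` gives 160000 nM, a true number. Compound 2 `CN(C)C(=O)CCCn1c2ccc([N+](=O)[O-])cc2c(=O)n1Cc1ccccc1` gives > 256000 nM, which is a limit and not a number. Compound 3 `COC(=O)COc1c2cc([N+](=O)[O-])ccc2nn1Cc1ccccc1` gives > 256000 nM, and this too is a limit. Compound 3 therefore has no exact position on the scale, and it shares its reading with compound 2, as the limit of > 256000 nM in this assay, at which 2 of the 3 values shown sit, shows.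

Compound 4 `COCCOc1c2cc([N+](=O)[O-])ccc2nn1Cc1ccccc1` differs from compound 3 on a saturated chain carbon bound to an oxygen on an aromatic ring: methoxymethyl in place of methoxycarbonyl on a saturated chain carbon bound to an oxygen on an aromatic ring. In short, methoxymethyl stands in place of methoxycarbonyl.

Within the data shown here, no measured step tests this exact change. Among the measured compounds shown here, the only step available, an at least 1.6-fold higher number from compound 1 to compound 2 (0.20 log units; that floor lies within the scatter), concerns a different group on an aromatic nitrogen, so it offers only weak guidance. It gives no direction for the present change, and no step beyond the usual scatter is expected. With only a limit for compound 3, the expected step can be stated only loosely, as a step that the limit leaves unreadable from compound 3 to compound 4. The reading for compound 4 may well turn out to be a limit again. The estimate for compound 4 is 260000 nM, with an expected range from 130000 nM to 520000 nM.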

Compound 4, concentration lethal to 50% of the cells: > 256000 nM
Compound 4 gave a limit, no number; the forecaster's own chance of this, stated with the estimate: 65%; the middle value does not contradict the limit.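

In this assay compound 4 gives a limit and not a number, just as compound 3 does, so no step can be read between these two compounds: the limit of > 256000 nM in this assay, at which 3 of the 4 values shown sit. The compounds shown leave open how far apart compound 3 and compound 4 truly lie, and whether methoxymethyl in place of methoxycarbonyl changes the reading at all.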